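The source may report more compounds than this note shows. Statements on the series, on what has been measured and on what is new or still open speak of the compounds shown alone.

Measured compounds in a physicochemical assay for solubility, read by LC-MS, in phosphate buffer, with a stated time of 24 h, at pH 7.4; on this read-out higher numbers stand for higher solubility and lower numbers for lower solubility:

compound 1 `C[C@@H]1CC(=O)N(c2cnc(NCc3c(F)ccc4c3CCO4)n3cnnc23)C1`: 130000 nM
compound 2 `Cc1ncccc1-c1cnc(NCc2c(F)ccc3c2CCO3)c2ncc(=O)[nH]c12`: 29000 nM
compound 3 `CN(C)Cc1ccc2c(c1)CN(c1cnc(NCc3c(F)ccc4c3CCO4)n3cnnc13)C2=O`: 12000 nM

Compound 1 gives the highest number of the three in this assay. Compound 2 sits below it by a gap beyond the usual scatter, and compound 3 further below, again beyond the scatter, so compound 1 is the most soluble compound measured here.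

Compound 4 `O=C(Nc1cnc(NCc2c(F)ccc3c2CCO3)n2cnnc12)c1ccccc1` has not yet been measured. It differs from compound 1 in one place: benzamido in place of 4-methyl-2-oxopyrrolidin-1-yl on an aromatic carbon. Within the data shown here, nothing measured here shows the effect of this change directly, since no pair of measured compounds differs by exactly this exchange. Still, a group of 7 heavy atoms with 0 hydrogen-bond donors gives way to one of 9 heavy atoms with 1 hydrogen-bond donor and an aromatic ring, and on that basis a drop in solubility beyond the scatter is expected, a step estimated at a 3.7-fold lower number from compound 1 to compound 4 (0.57 log units; beyond the scatter). The estimated solubility of compound 4 in this assay is 35000 nM, with a range from 8000 nM to 130000 nM.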

Compound 4, solubility: 2000 nM
The estimate for compound 4 lay 18-fold (1.24 log units) above the measured number; the whole stated range lies above it.
By their numbers in this assay, from the lowest: compound 4; then compound 3; then compound 2; then compound 1.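

In this assay, among these compounds, the exchange of 4-methyl-2-oxopyrrolidin-1-yl for benzamido on this aromatic carbon comes with a 65-fold lower number from compound 1 to compound 4 (1.81 log units; beyond the scatter), the first step here between two compounds that differ in one place, and it shows that the group at this position can go with a large change on the shared core. The exchange alters several things at once: an aromatic ring of carbon only enters, a hydrogen-bond donor is added, and the defined stereocentre is lost, so this single step cannot separate their contributions. No measurement shown here explains the step.

Going by these compounds, it remains open how the number would respond to acetamido, which has the amide hydrogen but no aromatic ring. The same question stands for a benzamido group carrying an amine on its ring.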